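Cyano for ethyl on a weakly active core

A few compounds are considered here, and "the series" means these few. Any claim that something is new, unique, unknown or untested is made for them only; others in the source may bear on it.

- compound 1 `CC1(C)c2ccc([N+](=O)[O-])cc2[C@@H](N2CCCCC2=O)[C@H]1O`: 350 nM 
- compound 2 `CCc1ccc2c(c1)C(C)(C)[C@@H](O)[C@@H]2N1CCCCC1=O`: > 20000 nM 

In a functional assay (trachea) for inhibition, with Cavia porcellus as the target (a higher number here means a weaker inhibitor, a lower number a stronger inhibitor), compound 1 gives 350 nM as a measured number. Compound 2 gives > 20000 nM and this value is a limit of the assay, not a number. Compound 2 thus stands at the limit of > 20000 nM in this assay, at which 1 of the 2 values shown sits, and has no measured number of its own.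

Compound 3 `CC1(C)c2cc(C#N)ccc2[C@@H](N2CCCCC2=O)[C@@H]1O` carries cyano in place of ethyl on an aromatic carbon and is otherwise the same as compound 2. Going by the values given here, no measured pair shows what such a change does in this assay so far. A moderate gain in strength is expected, though compound 3 may also remain at the limit. The expected change is an at least 2.5-fold lower number from compound 2 to compound 3 (0.39 log units; beyond the scatter) as far as a limit allows. For compound 3 the estimate is 8000 nM with an expected range from 1500 nM to 30000 nM in this assay.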

Compound 3, half-maximal inhibitory concentration: > 20000 nM
Compound 3: only a limit was reported; the forecaster's own chance of this, stated with the estimate: 45%; at least 2.5-fold (0.39 log units) between middle value and limit.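

In this assay, compound 2 and compound 3 both give a limit and not a number, so no step can be read between them: the limit of > 20000 nM in this assay, at which 2 of the 3 values shown sit.

The compounds shown leave open whether cyano in place of ethyl on an aromatic carbon changes the strength of inhibition at all.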